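A few compounds are considered here, and "the series" means these few. Any claim that something is new, unique, unknown or untested is made for them only; others in the source may bear on it.

In a functional assay on SK-MEL-2 cells (Homo sapiens) for cytotoxicity (a lower number here means a stronger inhibitor, a higher number a weaker inhibitor), compound 1 `Cc1ccc(S(=O)(=O)N2C(=O)NCC2c2ccc(Br)cc2)cc1` gives 80000 nM, compound 2 `O=C1NCC(c2ccc(Br)cc2)N1S(=O)(=O)c1ccc(Cl)cc1` gives 106000 nM, and compound 3 `O=C1NCC(c2ccc(Br)cc2)N1S(=O)(=O)c1ccc2c(c1)CCC2` gives 119000 nM. Compound 2 therefore lies within the usual scatter of both other compounds. Compound 4 `Cc1ccc(C2CNC(=O)N2S(=O)(=O)c2ccc(Cl)cc2)cc1` differs from compound 2 by having methyl in place of bromo on an aromatic carbon. For the measured compounds named here, the only measured step available as a guide is a 1.3-fold higher number from compound 1 to compound 2 (0.12 log units; within the scatter). That step exchanges methyl for chloro, not bromo for methyl, so it bears on the new change only loosely. No step beyond the scatter is expected in this assay, and the estimated step is a 1.1-fold lower number from compound 2 to compound 4 (0.03 log units; within the scatter). The estimated value for compound 4 is 100000 nM, with an expected range of 50000 nM to 200000 nM.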

Compound 4, half-maximal inhibitory concentration: 255000 nM
The estimate for compound 4 lay 2.6-fold (0.41 log units) below the measured number, outside the stated range (above it).
By their numbers in this assay, from the lowest: compounds 1, 2 and 3 (each within the scatter of the next); then compound 4.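

In this assay, the place on the aromatic ring that carries bromo in compound 2 is sensitive to change: a 2.4-fold higher number from compound 2 to compound 4 (0.38 log units; beyond the scatter), so methyl gives a weaker inhibitor here. The only earlier step, a 1.3-fold higher number from compound 1 to compound 2 (0.12 log units; within the scatter), stayed within the scatter, so this is the first change among these compounds to shift the number measurably. Nothing available explains why this exchange matters. On these data alone, whether an amine, a carboxylic acid or a longer chain at this place would match bromo or methyl remains open. So does whether bromo to methyl gives a similar step alongside the other groups in compound 1 and compound 3.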